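A few compounds are considered here, and "the series" means these few. Any claim that something is new, unique, unknown or untested is made for them only; others in the source may bear on it.

Compound 1 `COc1ccc(C2N=C(SCc3ccc(F)cc3)NC(C)=C2C(=O)Nc2ccc(F)cc2)cc1OC` gives 37.9% in a functional assay on the whole organism (artery, strain albino) with Rattus norvegicus as the target, with a stated time of 300 min, at a dose of 10 mg/kg by the oral route; on this read-out lower numbers stand for less inhibition and higher numbers for more inhibition at the one dose given (going by the name of the read-out).
Compound 2 `CC1=C(C(=O)Nc2ccc(F)cc2)C(c2ccc([N+](=O)[O-])cc2)N=C(SCc2ccc(Cl)cc2)N1` gives 37.9% in this assay.

Going by the values given here, the two compounds measured so far share a core and differ at two places at once, one on the aryl group carried by the core and one on the benzyl group of the sulfanyl side chain; no single-change step is therefore available between them. On the numbers shown, compound 2 stands level with compound 1 at the digits given, the gap between them lying within the usual scatter of this assay.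

Compound 3 `CC1=C(C(=O)Nc2ccc(F)cc2)C(c2ccc([N+](=O)[O-])cc2)N=C(SCc2ccc(F)cc2)N1` has not yet been measured. It differs from compound 2 in one place only: fluoro in place of chloro on an aromatic carbon. Compound 1 already carries the 4-fluorobenzyl group on its sulfanyl side chain and sits level with compound 2, so the change itself has given no sign of moving the read-out. No step beyond the scatter is expected in this assay for this change. For compound 3 the inhibition is estimated at 38%, with a range from 24% to 52%, which means an expected step of a number 0.1 percentage points higher from compound 2 to compound 3 (within the scatter).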

Compound 3, a percentage reported as inhibition, in the whole organism at one dose (the size of the read-out at that dose, not a potency): 30.3%
The estimate for compound 3 lay 7.7 percentage points above the measured number; measured number inside the range.
By their numbers in this assay, from the lowest: compounds 3, 1 and 2 (each within the scatter of the next).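

Fluoro in place of chloro on an aromatic carbon, para to a large group, now has a direct reading: with the rest of the molecule held fixed, the change gives a number 7.6 percentage points lower from compound 2 to compound 3 (within the scatter) in this assay and so does not separate the 4-chlorobenzyl from the 4-fluorobenzyl side chain on this read-out. The earlier pair changed at two places at once, whereas compound 1 and compound 3 both carry (4-fluorobenzyl)sulfanyl and isolate the aryl group on the core: 4-nitrophenyl in place of 3,4-dimethoxyphenyl on a saturated ring carbon gives a number 7.6 percentage points lower from compound 1 to compound 3 (within the scatter) at the one dose tested, so neither change is shown here to move the inhibition beyond the usual scatter. Nothing available bears on the reasons behind these readings.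

Still open, going by these compounds, is whether a group of a different kind at this place on the benzyl ring, such as a methoxy group, a trifluoromethyl group or an amine, would give a step beyond the scatter. On these data alone, it is equally open whether replacing the benzyl group on the sulfur with a longer chain, or the 4-nitrophenyl group with a carboxylic acid-bearing phenyl group, would do so.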